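Removing the last bromo: from compound 3 to compound 4

The compounds below may be only part of what the source reports. "The series", "measured", "known", "first", "only" and "open" are said of these compounds alone.

Measured compounds:
Compound 1, `COC(=O)c1c(Br)cc(Br)cc1OC(=O)COc1cc(O)c2c(=O)cc(-c3ccccc3)oc2c1`, gives 45700 nM in a functional assay on cells (T-cell, Mus musculus, strain BALB/c) for inhibition, read by MTT assay, with a stated time of 72 h; a higher number here means a weaker inhibitor, a lower number a stronger inhibitor.
Compound 2, `COC(=O)c1cccc(OC)c1OC(=O)COc1cc(O)c2c(=O)cc(-c3ccccc3)oc2c1`, gives 36800 nM in this assay.
Compound 3, `COC(=O)c1c(Br)cccc1OC(=O)COc1cc(O)c2c(=O)cc(-c3ccccc3)oc2c1`, gives 41700 nM in this assay.

Compound 3 stands second highest of the three numbers. Its nearest neighbour is compound 1, and the step is a 1.1-fold lower number from compound 1 to compound 3 (0.04 log units; within the scatter). Among the measured compounds shown here, compound 2 has no single-change step to compound 3; its number and that of compound 3 lie within the scatter of each other.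

Compound 4, `COC(=O)c1ccccc1OC(=O)COc1cc(O)c2c(=O)cc(-c3ccccc3)oc2c1`, differs from compound 3 by hydrogen in place of bromo on an aromatic carbon. For the measured compounds named here, the one step that bears on this change is a 1.1-fold lower number from compound 1 to compound 3 (0.04 log units; within the scatter), the same kind of change, and it was within the scatter. Compound 4 is therefore expected to show a 1.0-fold lower number from compound 3 to compound 4 (0.02 log units; within the scatter), with no step beyond the scatter in this assay. The estimate for compound 4 is 40000 nM, with a range from 20000 nM to 80000 nM.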

Compound 4, half-maximal inhibitory concentration: 28500 nM
Estimate against measurement, compound 4: 1.4-fold (0.15 log units) above; the range from low to high includes it.
By their numbers in this assay, from the lowest: compounds 4, 2, 3 and 1 (each within the scatter of the next).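

Taking off the last bromo, ortho to a methoxycarbonyl group, gives a 1.5-fold lower number from compound 3 to compound 4 (0.17 log units; within the scatter) in this assay, so this change stays within the scatter even when it leaves no bromo on the ring. Hydrogen in place of methoxy gives a 1.3-fold lower number from compound 2 to compound 4 (0.11 log units; within the scatter), which is also within the scatter. Nothing measured here points to a cause for these steps.

As far as these compounds go, whether an amine or a carboxylic acid at this position would give a step beyond the scatter remains open. So does the effect of replacing the methoxycarbonyl group itself.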